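The source may report more compounds than this note shows. Statements on the series, on what has been measured and on what is new or still open speak of the compounds shown alone.

Three compounds share one core and were all tested in a functional assay on HT-29 cells (Homo sapiens) for cytotoxicity, read by sulforhodamine B assay; on this read-out higher numbers stand for weaker inhibition of growth and lower numbers for stronger inhibition of growth. Compound 1 `CC1=CC[C@@H]([C@@](C)(O)CCCC(C)(C)NC(=S)NN)CC1` carries the unsubstituted arm, and in this assay compound 1 gives 49400 nM. Compound 2 `CC1=CC[C@@H]([C@@](C)(O)CCCC(C)(C)NC(=S)N/N=C\c2ccccc2)CC1` has a group with a six-membered aromatic ring in place of one nitrogen on the amide-type nitrogen, and in this assay compound 2 gives 9960 nM. Compound 3 `CC1=CC[C@@H]([C@@](C)(O)CCCC(C)(C)NC(=S)N/N=C\c2ccc(C)cc2)CC1` carries the same aromatic group with a methyl on the ring, and in this assay compound 3 gives 10400 nM. Compound 3 therefore stands second of the three numbers: its gap to compound 2 lies within the scatter, while against compound 1 the step is a 4.8-fold lower number from compound 1 to compound 3 (0.68 log units; beyond the scatter).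

Compound 4 `COc1ccc(/C=N\NC(=S)NC(C)(C)CCC[C@](C)(O)[C@@H]2CC=C(C)CC2)cc1` is the next step: methoxy in place of methyl on an aromatic carbon. The measured step that bears on it most directly is a 1.0-fold higher number from compound 2 to compound 3 (0.02 log units; within the scatter), a small change on the same aromatic ring that left the number where it was. The larger steps, a 5.0-fold lower number from compound 1 to compound 2 (0.70 log units; beyond the scatter) and a 4.8-fold lower number from compound 1 to compound 3 (0.68 log units; beyond the scatter), came from adding the whole aromatic group, not from what sits on it. No step beyond the scatter is therefore expected in this assay. For compound 4 the expected value is 10000 nM, with a range from 4000 nM to 25000 nM. The expected step is a 1.0-fold lower number from compound 3 to compound 4 (0.02 log units; within the scatter).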

Compound 4, concentration for 50% growth inhibition: 7420 nM
Compound 4: the middle estimate sits 1.3-fold (0.13 log units) above what was measured; the measured number falls inside the stated range.
By their numbers in this assay, from the lowest: compounds 4, 2 and 3 (each within the scatter of the next); then compound 1.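

In this assay the change from the 4-methylphenyl to the 4-methoxyphenyl group gives a 1.4-fold lower number from compound 3 to compound 4 (0.15 log units; within the scatter) and methoxy in place of the hydrogen of compound 2 gives a 1.3-fold lower number from compound 2 to compound 4 (0.13 log units; within the scatter) so this ring position has now held hydrogen, methyl and methoxy with no step beyond the scatter. Methoxy differs from methyl in adding an oxygen and a hydrogen-bond acceptor, and even this change leaves the number within the scatter, which the earlier methyl step alone could not show. Going by these compounds alone, the only step involving compound 4 that lies beyond the scatter is a 6.7-fold lower number from compound 1 to compound 4 (0.82 log units; beyond the scatter) and it again comes with the whole aromatic group rather than with what sits on it, while no measurement here accounts for these numbers.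

Going by these compounds, whether an amine, a carboxylic acid or a longer chain at this same ring position would move the number beyond the scatter remains open. Also open, on these data alone, is whether methoxy would give the same result on a different carbon of the ring.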